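Triazole in place of dioxoimidazolidinyl on the side chain

The source may hold more compounds than are shown below. What is called first, only, known or untested is meant among the compounds shown, and "the series" means these compounds.

Three compounds of the series have a number in a physicochemical assay for lipophilicity, read by HPLC, measured as octanol-water partition; on this read-out higher numbers stand for higher lipophilicity and lower numbers for lower lipophilicity. Compound 1 `CN(CCC#N)C[C@H]1CN(c2ccc(-n3cc(-c4ccccn4)cn3)c(F)c2)C(=O)O1` gives 1.9. Compound 2 `O=C1O[C@@H](CN2CCC(c3ccc(F)cc3)CC2)CN1c1ccc(-n2cc(-c3ccccn3)cn2)c(F)c1` gives 5.78, far above the other two. Compound 3 `O=C1CNC(=O)N1C[C@H]1CN(c2ccc(-n3cc(-c4ccccn4)cn3)c(F)c2)C(=O)O1` gives 1.25, the lowest of the three, with compound 1 as its nearest neighbour and compound 2 furthest away. Within the data shown here, the only measured step between compounds that differ in one place is a number 0.65 log units lower from compound 1 to compound 3 (beyond the scatter); it shows that exchanging the group on the saturated chain carbon bound to the saturated ring carbon shifts this assay by a modest amount.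

Compound 4 `O=C1O[C@@H](Cn2ccnn2)CN1c1ccc(-n2cc(-c3ccccn3)cn2)c(F)c1` has not yet been measured in this assay. Its difference from compound 3 is 1H-1,2,3-triazol-1-yl in place of 2,5-dioxoimidazolidin-1-yl on a saturated chain carbon bound to a saturated ring carbon. Among the measured compounds shown here, no measured pair swaps exactly these two groups, so the bearing of the known step is indirect: the group that leaves in compound 4 is the one that entered in the measured step, and what enters is smaller by heavy-atom count, aromatic, and carries no hydrogen-bond donor. A modest rise is therefore expected; the step from compound 3 to compound 4 is estimated as a number 0.45 log units higher from compound 3 to compound 4 (beyond the scatter). Compound 4 is expected to read 1.7, within a range from 1.2 to 2.3.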

Compound 4, partition coefficient: 2
Beside the measured number, compound 4's estimate is 0.30 log units below it, and the stated range covers the measured number.
By their numbers in this assay, from the lowest: compound 3; then compounds 1 and 4 (each within the scatter of the next); then compound 2.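

On the saturated chain carbon bound to a saturated ring carbon, 1H-1,2,3-triazol-1-yl in place of 2,5-dioxoimidazolidin-1-yl gives in this assay a number 0.75 log units higher from compound 3 to compound 4 (beyond the scatter) and is the second exchange at this position to move the 2,5-dioxoimidazolidin-1-yl compound beyond the scatter. 1H-1,2,3-triazol-1-yl in place of (2-cyanoethyl)(methyl)amino gives a number 0.10 log units higher from compound 1 to compound 4 (within the scatter) in the same read-out, so a five-membered aromatic ring and an open chain ending in a nitrile read alike here, and the 2,5-dioxoimidazolidin-1-yl compound is the one that stands apart among these three. No measurement on hand assigns the step to any one feature of the exchange, whether ring type, heavy-atom count or the amide hydrogen.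

The compounds shown leave open whether 3-methyl-2,5-dioxoimidazolidin-1-yl, which has a methyl group in place of the amide hydrogen, would stay with compound 3 or move towards compound 4. They also leave open how 1H-1,2,4-triazol-1-yl, a tetrazole, a primary amine or a carboxylic acid would read on the same carbon.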